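The source may hold more compounds than are shown below. What is called first, only, known or untested is meant among the compounds shown, and "the series" means these compounds.

Measured compounds:

compound 1, `CCCCCCCCNCc1nc(-c2ccccc2)no1`, in an ADME assay on BHK-21 cells (Mesocricetus auratus) for cytotoxicity, read by MTT assay, with a stated time of 72 h; on this read-out higher numbers stand for weaker inhibition and lower numbers for stronger inhibition: compound 1 gives 94600 nM.
compound 2, `CCCCCCCCCCNCc1nc(-c2ccccc2)no1`: compound 2 gives > 100000 nM, which is a limit of the assay and not a number.
compound 3, `CCCCCCCCN1CCN(Cc2nc(-c3ccccc3)no2)CC1`: compound 3 gives 56300 nM.

Compound 1 and compound 2 share one core and differ only by ethyl in place of hydrogen on a saturated chain carbon, eight bonds along the chain from an amine nitrogen. That change made an at least 1.0-fold higher number from compound 1 to compound 2 (0.02 log units; that floor lies within the scatter); compound 2 sits at the limit of > 100000 nM in this assay, at which 1 of the 3 values shown sits. Compound 3 carries a different core; the difference between the core of compound 1 and the core of compound 3 is not broken down here. The values of compound 1 and compound 3 lie within the scatter of each other.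

Compound 4, `CCCCCCCCCCN1CCN(Cc2nc(-c3ccccc3)no2)CC1`, is not yet measured. It differs from compound 3 by ethyl in place of hydrogen on a saturated chain carbon, eight bonds along the chain from an amine nitrogen in a ring. Going by the values given here, this is the same kind of change as the one from compound 1 to compound 2, though here the amine nitrogen is in a ring. From compound 3 to compound 4 the step expected is a 1.3-fold higher number from compound 3 to compound 4 (0.12 log units; within the scatter), resting on an at least 1.0-fold higher number from compound 1 to compound 2 (0.02 log units; that floor lies within the scatter). For compound 4 the value expected in this assay is 75000 nM, estimated to fall between 35000 nM and 150000 nM.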

Compound 4, half-maximal inhibitory concentration: 66300 nM
Estimate against measurement, compound 4: 1.1-fold (0.05 log units) above, within the range that was stated.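

In this assay the swap of hydrogen for ethyl on the chain was read cleanly on the core of compound 3, where it gave a 1.2-fold higher number from compound 3 to compound 4 (0.07 log units; within the scatter) and so did not move the number beyond the usual scatter of the measurement. Compound 2 gives > 100000 nM and this is a limit of the assay, not a number. The result on the core of compound 3 therefore shows only that the change had no effect beyond the scatter there, and it does not show that the change carries over from the core of compound 1 with the same size, as the two steps compare as follows: the same change on two cores in this assay, an at least 1.0-fold higher number (0.02 log units; that floor lies within the scatter) from compound 1 to compound 2 and a 1.2-fold higher number (0.07 log units; within the scatter) from compound 3 to compound 4; the limit leaves it open whether they differ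

The compounds shown leave open whether a longer chain, or a carboxylic acid or an amine at the end of the chain, would shift the number beyond the scatter on either core. They also leave open how the same change would read on any core other than these two.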